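From Cyano to Propargyl on the Amide Chain

The source may report more compounds than this note shows. Statements on the series, on what has been measured and on what is new or still open speak of the compounds shown alone.

In a functional assay on MIA PaCa-2 cells (Homo sapiens) for antiproliferative activity (on this read-out lower numbers stand for an effect already at smaller amounts and higher numbers for an effect only at larger amounts of compound), compound 1 (`C#CCNC(=O)c1cccc2c1cc(C)n2-c1nc2c(c(NCc3ccccc3)n1)CCCC2`) gives 470 nM as its half-maximal concentration, and compound 2 (`Cc1cc2c(C(=O)NCC#N)cccc2n1-c1nc2c(c(NCc3ccccc3)n1)CCCC2`) gives 468 nM on the same read-out, so compound 2 stands level with compound 1 within the scatter. Compound 3 (`C#CCCNC(=O)c1cccc2c1cc(C)n2-c1nc2c(c(NCc3ccccc3)n1)CCCC2`) is related to compound 2 by one structural change, propargyl in place of cyano on a saturated chain carbon bound to an amide-type nitrogen in words, propargyl in place of cyano on a saturated chain carbon bound to an amide-type nitrogen. Within the data shown here, the only measured step that bears on this is a 1.0-fold lower number from compound 1 to compound 2 (0.00 log units; within the scatter) at the same place, and it stays within the scatter. That single pair is thin support, but it gives no reason to expect a real shift in this assay in either direction. The step expected is a 1.1-fold higher number from compound 2 to compound 3 (0.03 log units; within the scatter) and so remains within the scatter. For compound 3 the estimate is 500 nM as the expected value, with an expected range from 200 nM to 1200 nM as its bounds.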

Compound 3, half-maximal effective concentration: 1410 nM
Compound 3: the middle estimate sits 2.8-fold (0.45 log units) below what was measured; measured number above the stated range.
By their numbers in this assay, from the lowest: compounds 2 and 1 (each within the scatter of the next); then compound 3.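

The step of a 3.0-fold higher number from compound 2 to compound 3 (0.48 log units; beyond the scatter) and the step of a 3.0-fold higher number from compound 1 to compound 3 (0.48 log units; beyond the scatter) show in this assay that this position is not indifferent to every change on the amide chain. Ethynyl and cyano on the saturated chain carbon had left the number where it was, whereas propargyl at that carbon, which gives the but-3-yn-1-yl chain, sets compound 3 apart from both compound 1 and compound 2, though only modestly. Nothing available accounts for this shift.

Going by these compounds, it remains open whether a still longer chain would raise the number further, or whether the step follows the but-3-yn-1-yl chain itself. A nitrile on the longer chain, or an amine or a carboxylic acid at its end, would help separate these readings.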